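Alkyne substituent and cytotoxicity: compounds 1 to 3

The compounds below may be only part of what the source reports. "The series", "measured", "known", "first", "only" and "open" are said of these compounds alone.

- compound 1 `O=[N+]([O-])c1c(CS(=O)(=O)c2ccccc2)nc2c(C#Cc3cccc(F)c3)cc(Cl)cn12`: > 3900 nM (a limit)
- compound 2 `O=[N+]([O-])c1c(CS(=O)(=O)c2ccccc2)nc2c(C#CCCO)cc(Cl)cn12`: > 125000 nM (a limit)
- compound 3 `O=[N+]([O-])c1c(CS(=O)(=O)c2ccccc2)nc2c(C#CC3(O)CCCCC3)cc(Cl)cn12`: not yet measured

All readings come from an ADME assay on HepG2 cells (Homo sapiens) for cytotoxicity, read by MTT assay, with a stated time of 72 h; a lower number here means that less compound is tolerated, a higher number that more compound is tolerated. Compound 2 gives > 125000 nM, which is a limit and not a number. Compound 1 gives > 3900 nM, which is also a limit. Among the measured compounds shown here, compound 2 thus has no numerical reading to start from, and neither does the only other measured compound.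

Compound 3 keeps the shared core and changes one group: 1-hydroxycyclohexyl in place of 2-hydroxyethyl on a triple-bonded carbon. The same difference reads 4-hydroxybut-1-yn-1-yl to 2-(1-hydroxycyclohexyl)ethynyl.

For the measured compounds named here, the only measured step on this carbon is a step that the two limits leave unreadable from compound 1 to compound 2. It offers no size to carry over, so any expectation stays loose. Compound 1 also carries a ring on that carbon, and its > 3900 nM is a limit. The expected change is an at least 4.1-fold lower number from compound 2 to compound 3 (0.61 log units; beyond the scatter), in the direction of less compound tolerated, and a limit reading would not be surprising. Compound 3 is estimated at 30000 nM, with an expected range of 8000 nM to 125000 nM.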

Compound 3, half-maximal cytotoxic concentration: > 25000 nM
Compound 3: only a limit was reported (the forecaster's own chance of this, stated with the estimate: 60%); the middle value does not contradict the limit.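

In this assay compound 3 gives > 25000 nM, which is a limit and not a number. Among the compounds shown here, compound 1 and compound 2 also stand only as limits, so no step among compound 1, compound 2 and compound 3 can be read. The compounds shown leave open whether 3-fluorophenyl, 2-hydroxyethyl and 1-hydroxycyclohexyl differ at all in the concentration tolerated.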